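This account rests on a few compounds, and the source may have more. Where it says the series, first, only, none or still open, it means among the compounds named here.

Of the compounds shown here, three that share one core have been measured in a physicochemical assay for lipophilicity, read by HPLC, measured as octanol-water partition; on this read-out higher numbers stand for higher lipophilicity and lower numbers for lower lipophilicity. Compound 1 `CN1CCN(C[C@H]2CN(c3ccc(-n4cc(-c5ccccn5)cn4)c(F)c3)C(=O)O2)CC1` gives 2.2. Compound 2 `O=C1O[C@@H](CN2CCCCC2)CN1c1ccc(-n2cc(-c3ccccn3)cn2)c(F)c1` gives 3.1, the highest of the three numbers, each of the other two standing beyond the scatter from it. Compound 3 `CCC(=O)NC[C@H]1CN(c2ccc(-n3cc(-c4ccccn4)cn3)c(F)c2)C(=O)O1` gives 2.2. Among the steps, a number 0.90 log units higher from compound 1 to compound 2 (beyond the scatter), whereas no change at the digits printed from compound 1 to compound 3 (within the scatter), and a number 0.90 log units lower from compound 2 to compound 3 (beyond the scatter).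

Compound 4 `O=CNC[C@H]1CN(c2ccc(-n3cc(-c4ccccn4)cn3)c(F)c2)C(=O)O1` has not yet been measured in this assay. It differs from compound 2 in one place: formylamino in place of piperidin-1-yl on a saturated chain carbon bound to a saturated ring carbon. Among the compounds with values here, the step that bears most directly on this change is the one from compound 2 to compound 3, where propanoylamino took the place of piperidin-1-yl at the same position and a number 0.90 log units lower from compound 2 to compound 3 (beyond the scatter). Formylamino is the same kind of group as propanoylamino but smaller, and on a measure of partition a smaller group of this kind is usually read lower still. The step from compound 2 to compound 4 is therefore expected to be downward and somewhat larger than the step to compound 3, with a number 1.70 log units lower from compound 2 to compound 4 (beyond the scatter) as the expected change. Compound 4 is estimated at 1.4, with a likely range from 0.9 to 1.9.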

Compound 4, partition coefficient: 1.19
Compound 4: the middle estimate sits 0.21 log units above what was measured; the measured number falls inside the stated range.
By their numbers in this assay, from the lowest: compound 4; then compounds 1 and 3 (each within the scatter of the next); then compound 2.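

In this assay, hydrogen in place of ethyl on a carbonyl carbon gives a number 1.01 log units lower from compound 3 to compound 4 (beyond the scatter) and shows that the amide alone does not set the number at this position, since what sits on its carbonyl counts as well. Compound 1 and compound 3 read alike and might have marked a lower end for this position, yet formylamino in place of 4-methylpiperazin-1-yl gives a number 1.01 log units lower from compound 1 to compound 4 (beyond the scatter) and formylamino in place of piperidin-1-yl gives a number 1.91 log units lower from compound 2 to compound 4 (beyond the scatter) in this assay, which makes compound 4 the lowest of the four and widens the span seen here. Nothing at hand explains why the numbers move as they do.

From the compounds shown here alone, two amides cannot define a trend, so it remains open whether acetylamino would fall midway between them or whether a longer chain on the carbonyl, such as butanoylamino, would read higher still. Also open, going by these compounds, is how groups of another kind, such as a free amine or a carboxylic acid, would read on this saturated chain carbon.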